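This account rests on a few compounds, and the source may have more. Where it says the series, first, only, none or still open, it means among the compounds named here.

Measured so far:
compound 1 `Clc1ccccc1OCC1=NCCO1` — 40%
compound 2 `O=[N+]([O-])c1ccccc1OCC1=NCCO1` — 55%

In a toxicity assay on the whole organism with Rattus norvegicus as the target, at a dose of 200 mg/kg by the oral route (a higher number here means a stronger effect of the compound at the dose given, a lower number a weaker effect), compound 2 stands highest of the two numbers; its nearest neighbour is compound 1, which gives 40%, and the step of a number 15 percentage points higher from compound 1 to compound 2 (beyond the scatter) lies beyond the scatter. Compound 3 `Fc1ccccc1OCC1=NCCO1` has not yet been measured in this assay. It differs from compound 2 in one place: fluoro in place of nitro on an aromatic carbon. Within the data shown here, the only measured step bearing on this change is a number 15 percentage points higher from compound 1 to compound 2 (beyond the scatter), a modest rise for nitro in place of chloro on an aromatic carbon; the change to compound 3 removes the nitro group again and puts fluoro on that aromatic carbon. A downward step of comparable size is therefore expected: a number 15 percentage points lower from compound 2 to compound 3 (beyond the scatter). Compound 1 gives 40% with chloro on the aromatic carbon. Compound 3 is accordingly expected to come out near that figure, estimated at 40%, within 25% to 55%.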

Compound 3, a percentage reported as activity, at one dose (the size of the read-out at that dose, not a potency): 60%
Compound 3: the middle estimate sits 20 percentage points below what was measured, and the stated range ends below it.
By their numbers in this assay, from the lowest: compound 1; then compounds 2 and 3 (each within the scatter of the next).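

In this assay, a number 5 percentage points higher from compound 2 to compound 3 (within the scatter) shows that fluoro and nitro cannot be told apart on this aromatic carbon, even though fluoro has fewer heavy atoms and no hydrogen-bond acceptors. Chloro now stands apart from both: a number 20 percentage points higher from compound 1 to compound 3 (beyond the scatter) runs the same way as a number 15 percentage points higher from compound 1 to compound 2 (beyond the scatter), so among these three compounds it is the only group separated from the others, and heavy-atom count does not order the read-out. Nothing available here accounts for chloro standing apart from fluoro and nitro.

From the compounds shown here alone, it remains open whether a group such as an amine, a methoxy or a carboxylic acid on this carbon would fall with chloro or with fluoro and nitro. The read-out at a single dose also leaves open whether fluoro and nitro would stay indistinguishable at other doses.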